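From Chlorophenyl to Methoxyphenyl: Expecting the Next Value

This account rests on a few compounds, and the source may have more. Where it says the series, first, only, none or still open, it means among the compounds named here.

Within the data shown here, compound 1 `O=C1N=C(N2CCC[C@H]2C(=O)Nc2ccc3ncnc(Nc4cccc(Cl)c4)c3c2)S/C1=C/c1cccc(Cl)c1` gives 27600 nM in a functional assay on HepG2 cells (Homo sapiens) for antiproliferative activity, read by MTT assay (on this read-out higher numbers stand for weaker inhibition and lower numbers for stronger inhibition), the highest of the three numbers known here. Compound 3 `O=C1N=C(N2CCC[C@H]2C(=O)Nc2ccc3ncnc(Nc4cccc(Cl)c4)c3c2)S/C1=C/c1cccc(Br)c1`, which carries bromo in place of chloro on an aromatic carbon, gives 21300 nM, and the change a 1.3-fold lower number from compound 1 to compound 3 (0.11 log units; within the scatter) stays within the scatter. Compound 2 `Cc1cccc(/C=C2/SC(N3CCC[C@H]3C(=O)Nc3ccc4ncnc(Nc5cccc(Cl)c5)c4c3)=NC2=O)n1`, bearing 6-methylpyridin-2-yl on the double-bonded chain carbon, gives 4500 nM, a modest gain of a 6.1-fold lower number from compound 1 to compound 2 (0.79 log units; beyond the scatter).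

Compound 4 `COc1ccccc1/C=C1/SC(N2CCC[C@H]2C(=O)Nc2ccc3ncnc(Nc4cccc(Cl)c4)c3c2)=NC1=O` departs from compound 1 by 2-methoxyphenyl in place of 3-chlorophenyl on a double-bonded chain carbon bound to a double-bonded ring carbon. Among the measured compounds shown here, two measured steps bear on this: the swap of a halogen on the same ring left the number unchanged within scatter, while replacing the whole 3-chlorophenyl with a different group lowered the number by a 6.1-fold lower number from compound 1 to compound 2 (0.79 log units; beyond the scatter). A 2-methoxyphenyl group is a different ring again, so a step of similar or smaller size is conceivable but not assured.

Compound 4 is therefore expected to show a small improvement, a 1.8-fold lower number from compound 1 to compound 4 (0.26 log units; within the scatter), that may or may not exceed the scatter. The estimate for compound 4 in this assay is 15000 nM, with a plausible range from 5000 nM to 40000 nM.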

Compound 4, half-maximal inhibitory concentration: 22100 nM
The estimate for compound 4 lay 1.5-fold (0.17 log units) below the measured number; the measured number falls inside the stated range.
By their numbers in this assay, from the lowest: compound 2; then compounds 3, 4 and 1 (each within the scatter of the next).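

In this assay, 2-methoxyphenyl brings an oxygen and a hydrogen-bond acceptor to this position, yet compound 4 cannot be told apart from the halogen-bearing compounds: the data give a 1.2-fold lower number from compound 1 to compound 4 (0.10 log units; within the scatter) and a 1.0-fold higher number from compound 3 to compound 4 (0.02 log units; within the scatter). The earlier compounds had shown only a swap of one halogen for another on the same ring, so this result extends that flat stretch to a different group on a phenyl ring, named here as 2-methoxyphenyl rather than 3-chlorophenyl or 3-bromophenyl. Compound 2 remains the one exception among these four, with a 4.9-fold higher number from compound 2 to compound 4 (0.69 log units; beyond the scatter), and no measurement offered here accounts for that separation or for the flatness among compounds 1, 3 and 4.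

The compounds shown leave open whether the separation of compound 2 belongs to the ring nitrogen or to the methyl group of 6-methylpyridin-2-yl, a question that a plain pyridin-2-yl would address directly. They also leave open whether 3-methoxyphenyl would match compound 4, and whether a phenyl ring carrying an amine or a carboxylic acid at this position would stay with compounds 1, 3 and 4.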